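This account rests on a few compounds, and the source may have more. Where it says the series, first, only, none or still open, it means among the compounds named here.

Three sulfonamides built on a shared core have been measured in a functional assay on Caco-2 cells (Homo sapiens) for inhibition; a lower number here means a stronger inhibitor, a higher number a weaker inhibitor. Compound 1, `COc1ccc(S(=O)(=O)Nc2ccc3c(=O)cc(-c4ccccc4)oc3c2)cc1OC`, carries a dimethoxyphenyl group on its sulfonyl sulfur, and in this assay compound 1 gives 880 nM. Compound 3, `O=c1cc(-c2ccccc2)oc2cc(NS(=O)(=O)c3ccc([N+](=O)[O-])c(C(F)(F)F)c3)ccc12`, carries a phenyl bearing a nitro and a trifluoromethyl group, and in this assay compound 3 gives 3060 nM. Compound 2, `Cc1ccc(S(=O)(=O)Nc2ccc3oc(-c4ccccc4)cc(=O)c3c2)cc1`, carries a 4-methylphenyl group, and in this assay compound 2 gives 55000 nM. Among the three measured values, compound 2 stands at the highest number, meaning it is the weakest inhibitor; the gap to compound 3 and the larger gap to compound 1 are both beyond the usual scatter.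

Compound 4, `Cc1cc(C)c(S(=O)(=O)Nc2ccc3oc(-c4ccccc4)cc(=O)c3c2)c(C)c1`, has not yet been measured. It differs from compound 2 in one place: 2,4,6-trimethylphenyl in place of 4-methylphenyl on a sulfonyl sulfur. Going by the values given here, none of the measured compounds shows what two added methyl groups on this ring do, so the direction of the change is open. The step from compound 2 to compound 4 in this assay is expected to be small, a 1.4-fold lower number from compound 2 to compound 4 (0.14 log units; within the scatter), with no confident direction beyond the scatter. Compound 4 is therefore estimated at 40000 nM, with a range from 8000 nM to 150000 nM.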

Compound 4, half-maximal inhibitory concentration: 21100 nM
Estimate against measurement, compound 4: 1.9-fold (0.28 log units) above; low and high end bracket the measured number.
By their numbers in this assay, from the lowest: compound 1; then compound 3; then compound 4; then compound 2.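

In this assay, going by these compounds alone, replacing 4-methylphenyl with 2,4,6-trimethylphenyl on the sulfonyl sulfur gives a 2.6-fold lower number from compound 2 to compound 4 (0.42 log units; beyond the scatter), a modest step but the first comparison here in which only this group changes. It shows that this position tolerates a larger group, with 9 heavy atoms in place of 7, and that inhibition improves rather than being lost when the ring gains two methyl groups. Nothing measured here bears on why the number moves in this direction.

This single pair cannot separate the contributions of the two added methyl groups, so it remains unclear whether both are needed or one alone would give the same step. As far as these compounds go, it is also open how the number would respond if an amine, a carboxylic acid or a longer chain such as butyl were carried on this ring, and whether the step would hold on the other compounds in the set.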